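Lengthening the Chain: What to Expect Next

The compounds below may be only part of what the source reports. "The series", "measured", "known", "first", "only" and "open" are said of these compounds alone.

Three amides sharing one core have been tested in a functional assay on KB cells (Homo sapiens) for cytotoxicity, read by resazurin assay, with a stated time of 3 days; a higher number here means a weaker inhibitor, a lower number a stronger inhibitor. Compound 1 `CCCC(C)C(=O)NCC(C)(C)CC1=C(O)C(=O)c2ccccc2C1=O` gives 47100 nM, compound 2 `CCCCCCCC(=O)NCC(C)(C)CC1=C(O)C(=O)c2ccccc2C1=O` gives 24600 nM, and compound 3 `CCCCCCCCCCC(=O)NCC(C)(C)CC1=C(O)C(=O)c2ccccc2C1=O` gives 17600 nM. Compound 3 and compound 2 together hold the low end of these three numbers, and only compound 1 stands clearly apart from compound 3.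

The next compound, compound 4 `CCCCCCCCCCCCCCCCCC(=O)NCC(C)(C)CC1=C(O)C(=O)c2ccccc2C1=O`, extends the straight chain of compound 3. The change is heptyl in place of hydrogen on a saturated chain carbon, ten or more bonds along the chain from a carbonyl carbon.

Within the data shown here, three measured steps bear on this. The closest in kind is also a lengthening of a straight chain, and it gave a 1.4-fold lower number from compound 2 to compound 3 (0.15 log units; within the scatter). The other two replace the 1-methylbutyl group of compound 1 with a longer straight chain. Heptyl gave a 1.9-fold lower number from compound 1 to compound 2 (0.28 log units; within the scatter), and decyl gave a 2.7-fold lower number from compound 1 to compound 3 (0.43 log units; beyond the scatter). Only the last of these clears the scatter, and it is modest, so only a small step towards a lower number is expected in this assay, probably one inside the scatter. The expected step is a 1.4-fold lower number from compound 3 to compound 4 (0.13 log units; within the scatter).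

Among the measured compounds shown here, no measured compound carries a chain this long, so the range has to stay wide and reach higher numbers too. The estimated value for compound 4 is 13000 nM, with an expected range of 5000 nM to 35000 nM.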

Compound 4, half-maximal inhibitory concentration: 6350 nM
Beside the measured number, compound 4's estimate is 2.0-fold (0.31 log units) above it; low and high end bracket the measured number.
By their numbers in this assay, from the lowest: compound 4; then compounds 3, 2 and 1 (each within the scatter of the next, the first and the last beyond it).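

This result shows that lengthening the straight chain can move the number beyond the scatter in this assay: heptyl in place of hydrogen, on a saturated chain carbon, gives a 2.8-fold lower number from compound 3 to compound 4 (0.44 log units; beyond the scatter), whereas the earlier lengthening gave only a 1.4-fold lower number from compound 2 to compound 3 (0.15 log units; within the scatter) and stayed within the scatter. The effect also holds across the two lengthenings taken together, since decyl in place of hydrogen, on a saturated chain carbon seven bonds along the chain from a carbonyl carbon, gives a 3.9-fold lower number from compound 2 to compound 4 (0.59 log units; beyond the scatter), and both of these steps are modest in size. Nothing available explains why the added chain carbons are followed by a lower number.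

Among the compounds shown, compound 4 carries the longest chain, so it remains open whether a longer chain would lower the number further, leave it unchanged or raise it. As far as these compounds go, it is also open whether an amine or a carboxylic acid on the chain would keep or lose the lower number seen with the plain heptyl extension.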